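This account rests on a few compounds, and the source may have more. Where it says the series, first, only, none or still open, it means among the compounds named here.

Compound 1 `CC(C)c1ccc(-c2nc(SCc3cn(CC(=O)NC(=O)Nc4ccccn4)nn3)nc(Nc3ccc(F)cc3)c2C#N)cc1` gives > 64000 nM in a functional assay on MCF7 cells (Homo sapiens) for inhibition, read by MTT assay, with a stated time of 72 h (a lower number here means a stronger inhibitor, a higher number a weaker inhibitor), a limit of the assay.
Compound 2 `CC(C)c1ccc(-c2nc(SCc3cn(CC(=O)NC(=O)Nc4ccccn4)nn3)nc(Nc3cccc([N+](=O)[O-])c3)c2C#N)cc1` gives 25900 nM in this assay.
Compound 3 `CC(C)c1ccc(-c2nc(SCc3cn(CC(=O)NC(=O)Nc4ccccn4)nn3)nc(Nc3ccccc3)c2C#N)cc1` gives > 64000 nM in this assay, a limit of the assay.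

Compound 1 stands at a limit, not at a number, and the same is true of one further value: the limit of > 64000 nM in this assay, at which 2 of the 3 values shown sit. Compound 4 `COc1ccc(Nc2nc(SCc3cn(CC(=O)NC(=O)Nc4ccccn4)nn3)nc(-c3ccc(C(C)C)cc3)c2C#N)cc1` differs from compound 1 in one place: methoxy in place of fluoro on an aromatic carbon. The measured steps touch the same ring but not this group. From compound 1 to compound 2 the step is an at least 2.4-fold lower number from compound 1 to compound 2 (0.39 log units; beyond the scatter); from compound 1 to compound 3 it is a step that the two limits leave unreadable from compound 1 to compound 3; from compound 2 to compound 3 it is an at least 2.4-fold higher number from compound 2 to compound 3 (0.39 log units; beyond the scatter). For the measured compounds named here, only the nitro group has moved a value off the limit; the change to methoxy has no measured counterpart here. Compound 4 is therefore expected to stay near the limit, a step that the limit leaves unreadable from compound 1 to compound 4 in this assay being the estimate. For compound 4 the expected value is 70000 nM, in a range from 20000 nM to 250000 nM.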

Compound 4, half-maximal inhibitory concentration: > 64000 nM
Compound 4: a limit, no number (the forecaster's own chance of this, stated with the estimate: 70%); the middle value is on the limit's open side.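

With methoxy on the aniline ring, compound 4 joins the compounds that sit at the limit in this assay, so fluoro, hydrogen and methoxy on this ring carbon have all left the value there: the limit of > 64000 nM in this assay, at which 3 of the 4 values shown sit. The steps among compounds 1, 3 and 4 cannot be read, since each has a limit at both ends and any difference among these three stays hidden. The one readable step is an at least 2.4-fold higher number from compound 2 to compound 4 (0.39 log units; beyond the scatter), which leaves compound 2, with its 3-nitrophenyl group, as the only compound shown that comes off the limit.

The compounds shown leave open whether that measured value belongs to the nitro group itself or to where it sits on the ring. They also leave open what an amine or a carboxylic acid on this ring would give.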